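The compounds below may be only part of what the source reports. "The series", "measured", "known", "first", "only" and "open" are said of these compounds alone.

Working notes on the series.

Compound 1 `Cc1nn(CC(=O)N2CCN(c3sc(C(F)(F)F)nc3-c3nc4ccccc4[nH]3)C[C@H]2C)cc1CN(C)C` is the weaker of the two measured compounds in a functional assay on Venous blood for antagonist activity at C-X-C chemokine receptor type 3 (Homo sapiens), read by flow cytometry, with a stated time of 30 min, in the presence of a further agent that is not named here (a lower number here means a stronger inhibitor, a higher number a weaker inhibitor), where compound 1 gives 330 nM. Among the compounds with values here, the only other measured member, compound 2 `Cc1nc(C)n(CC(=O)N2CCN(c3sc(C(F)(F)F)nc3-c3nc4ccc(C5CCOCC5)cc4[nH]3)C[C@H]2C)n1`, gives 123 nM in this assay; it differs from compound 1 in more than one place, so no single step connects the two, and the pair shows only that compound 2 sits at the lower number, a gap that lies beyond the scatter.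

Compound 3 `C[C@@H]1CN(c2sc(C(F)(F)F)nc2-c2nc3ccccc3[nH]2)CCN1C(=O)Cn1cnc2c1CCN(C)C2` is the unmeasured analogue of compound 1. The change is a group of 10 heavy atoms (7 carbon, 3 nitrogen; one five-membered aromatic ring with 2 hetero atoms, one six-membered non-aromatic ring with 1 hetero atom) in place of a group of 10 heavy atoms (7 carbon, 3 nitrogen; one five-membered aromatic ring with 2 hetero atoms), on a saturated chain carbon bound to a carbonyl carbon. The two groups match in heavy-atom count, in element make-up and in the count of donors and acceptors; what differs is that the entering group carries an additional six-membered non-aromatic ring fused to its five-membered aromatic ring. Within the data shown here, no measured pair isolates a change of this kind, so the direction cannot be read from the data.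

Compound 3 is therefore expected to stay close to compound 1, with the step from compound 1 to compound 3 estimated as a 1.1-fold lower number from compound 1 to compound 3 (0.04 log units; within the scatter), not beyond the scatter. For compound 3 in this assay the expected value is 300 nM, within a range of 110 nM to 850 nM.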

Compound 3, half-maximal inhibitory concentration in the C-X-C chemokine receptor type 3 assay: 135 nM
Estimate against measurement, compound 3: 2.2-fold (0.35 log units) above, within the range that was stated.
By their numbers in the C-X-C chemokine receptor type 3 assay, from the lowest: compounds 2 and 3 (each within the scatter of the next); then compound 1.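

Within the data shown here, the first single-place step falls on the saturated chain carbon bound to a carbonyl carbon: in the C-X-C chemokine receptor type 3 assay, replacing 4-((dimethylamino)methyl)-3-methyl-1H-pyrazol-1-yl with a group of the same heavy-atom count and the same donor and acceptor counts, but with an additional six-membered non-aromatic ring, gives a 2.4-fold lower number from compound 1 to compound 3 (0.39 log units; beyond the scatter), so this position responds to a change of ring arrangement alone, modestly but beyond the scatter. Among these compounds, in a physicochemical assay for solubility, in simulated intestinal fluid (on this read-out higher numbers stand for higher solubility and lower numbers for lower solubility), the same change reads an at least 1.4-fold higher number from compound 1 to compound 3 (0.15 log units; that floor lies within the scatter), which is a floor and not a measured size, so this pair fixes no size for the step on that read-out. In the physicochemical assay compound 1 gives 649 ug/mL as a measured value. In the physicochemical assay compound 3 gives > 920 ug/mL as a limit of the assay and not a number: the limit of > 920 ug/mL in the physicochemical assay, at which 1 of the 2 values shown sits.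

A single step cannot show whether the same replacement would hold on the core of compound 2, which differs from compound 3 in more than one place. It also leaves open how this position would respond to an open-chain tertiary amine, a fused ring carrying oxygen in place of the ring nitrogen, or a carboxylic acid.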